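Dropping the Isopropyl Group: an Estimate for Compound 4

The compounds below may be only part of what the source reports. "The series", "measured", "known", "first", "only" and "open" are said of these compounds alone.

Measured compounds:
compound 1, `COc1ccc(Oc2ccccc2-c2ccsc2S(=O)(=O)NCCNC(=S)Nc2cc(C(F)(F)F)cc(C(F)(F)F)c2)cc1OC`, gives 6800 nM
compound 2, `COc1ccc(Oc2ccc(C(C)C)cc2-c2ccsc2S(=O)(=O)NCCNC(=S)Nc2cc(C(F)(F)F)cc(C(F)(F)F)c2)cc1OC`, gives 10200 nM
compound 3, `CC(C)c1ccc(Oc2ccc(O)c(O)c2)c(-c2ccsc2S(=O)(=O)NCCNC(=S)Nc2cc(C(F)(F)F)cc(C(F)(F)F)c2)c1`, gives 18100 nM

Of the compounds shown here, three of a shared core have been tested in an ADME assay on HEK-293T cells (Homo sapiens) for cytotoxicity, read by CCK-8 assay, with a stated time of 48 h; on this read-out higher numbers stand for weaker inhibition and lower numbers for stronger inhibition. Compound 2 carries both an isopropyl group and a 3,4-dimethoxyphenoxy group. Compound 1 differs from it by hydrogen in place of isopropyl on an aromatic carbon, and that step reads a 1.5-fold lower number from compound 2 to compound 1 (0.18 log units; within the scatter). Compound 3 differs from compound 2 by 3,4-dihydroxyphenyl in place of 3,4-dimethoxyphenyl on an oxygen on an aromatic ring, giving a 1.8-fold higher number from compound 2 to compound 3 (0.25 log units; within the scatter). Compound 3 holds the highest of the three numbers, but only its gap to compound 1 lies beyond the scatter, so no firm ranking follows.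

Compound 4, `O=S(=O)(NCCNC(=S)Nc1cc(C(F)(F)F)cc(C(F)(F)F)c1)c1sccc1-c1ccccc1Oc1ccc(O)c(O)c1`, has not been measured. It differs from compound 3 by hydrogen in place of isopropyl on an aromatic carbon. This is the same kind of change as from compound 2 to compound 1, not the same one: there the place was para to a 3,4-dimethoxyphenoxy group, here it is para to a 3,4-dihydroxyphenoxy group. Among the measured compounds shown here, the only measured instance of this change is a 1.5-fold lower number from compound 2 to compound 1 (0.18 log units; within the scatter), a step within the scatter. In this assay compound 4 is therefore expected to show a 1.5-fold lower number from compound 3 to compound 4 (0.18 log units; within the scatter), resting on that earlier step and on compound 3 at 18100 nM. Compound 4 is estimated at 12000 nM, with a range from 5000 nM to 30000 nM.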

Compound 4, half-maximal inhibitory concentration: 7500 nM
Compound 4: the middle estimate sits 1.6-fold (0.20 log units) above what was measured; the measured number falls inside the stated range.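

In this assay, hydrogen in place of isopropyl gives a 2.4-fold lower number from compound 3 to compound 4 (0.38 log units; beyond the scatter), and 3,4-dihydroxyphenyl in place of 3,4-dimethoxyphenyl gives a 1.1-fold higher number from compound 1 to compound 4 (0.04 log units; within the scatter). The isopropyl change points the same way on both cores and the two readings cannot be told apart, although only the newer step lies beyond the scatter, so the pair supports carrying the direction across but fixes no size for it: the same change on two cores in this assay, a 1.5-fold lower number (0.18 log units; within the scatter) from compound 2 to compound 1 and a 2.4-fold lower number (0.38 log units; beyond the scatter) from compound 3 to compound 4, 1.6-fold (0.21 log units) apart, within the scatter of two such steps. The change on the oxygen also reads alike on both cores, but both of its steps lie within the scatter, so it shows only that no effect of the core can be seen, and neither pair shows that a step would hold on a third core: the same change on two cores in this assay, a 1.8-fold higher number (0.25 log units; within the scatter) from compound 2 to compound 3 and a 1.1-fold higher number (0.04 log units; within the scatter) from compound 1 to compound 4, 1.6-fold (0.21 log units) apart, within the scatter of two such steps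

The compounds shown leave open how an amine or a carboxylic acid in place of isopropyl on that aromatic carbon would read in this assay. They also leave open whether a single hydroxyl or a fluorine in place of the 3,4-dihydroxyphenyl group's two hydroxyls, or a longer chain on the sulfonamide nitrogen, would move the number beyond the scatter.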